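The source may report more compounds than this note shows. Statements on the series, on what has been measured and on what is new or still open speak of the compounds shown alone.

Measured in a physicochemical assay for lipophilicity, at pH 7.4; a lower number here means a more polar compound, a higher number a more lipophilic compound:
- compound 1 `Cc1ccc(N(C2CCC2)S(=O)(=O)c2ccc3c(c2)C(O)CC(C2CCOCC2)O3)c(C)c1`: 3.77
- compound 2 `CC(C)CN(c1ccc(F)cc1)S(=O)(=O)c1ccc2c(c1)C(O)CC(C1CCOCC1)O2`: 3.39
- compound 3 `CCc1ccc(N(CC(C)C)S(=O)(=O)c2ccc3c(c2)C(O)CC(C2CCN(C(=O)C4CCCC4)CC2)O3)cc1`: 5.04

Compound 2 has the lowest of these three numbers. Compound 1 lies nearest to it and compound 3 furthest, both beyond the scatter. Compound 4 `CC(C)CN(c1ccccc1C(F)(F)F)S(=O)(=O)c1ccc2c(c1)C(O)CC(C1CCOCC1)O2` has not yet been measured. It differs from compound 2 in one place: 2-(trifluoromethyl)phenyl in place of 4-fluorophenyl on a sulfonamide nitrogen. This puts 2-(trifluoromethyl)phenyl in place of 4-fluorophenyl on a sulfonamide nitrogen.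

Within the data shown here, no two measured compounds differ in only one place, so the data offer no direct precedent for this change, and the expectation rests on the change itself. The entering group is the larger of the two, so a modest upward move in this assay is expected from compound 2, which stands at 3.39, probably just beyond the scatter. The expected change is a number 0.41 log units higher from compound 2 to compound 4 (beyond the scatter). For compound 4 the estimated value is 3.8, with an expected range of 3.4 to 4.25.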

Compound 4, distribution coefficient: 4.14
Compound 4: the middle estimate sits 0.34 log units below what was measured; measured number inside the range.
By their numbers in this assay, from the lowest: compound 2; then compound 1; then compound 4; then compound 3.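

On a sulfonamide nitrogen whose other neighbours are a saturated chain carbon and the sulfonyl sulfur, putting 2-(trifluoromethyl)phenyl in place of 4-fluorophenyl gives in this assay a number 0.75 log units higher from compound 2 to compound 4 (beyond the scatter) with the rest of the molecule unchanged. Among these compounds, this is the first step in the set with a single point of difference, so it shows that this aryl change alone moves the read-out beyond the scatter, which compounds 1, 2 and 3 could not show when compared with one another. Nothing available bears on why the number moves.

Going by these compounds, how much of the step belongs to the trifluoromethyl group and how much to the loss of fluorine remains open, and a plain phenyl or a 4-(trifluoromethyl)phenyl group on this nitrogen would separate the two. On these data alone, whether the step holds with a cyclobutyl group on the same nitrogen, in place of the chain, is also open.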